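The source may hold more compounds than are shown below. What is called first, only, known or untested is meant among the compounds shown, and "the series" means these compounds.

Working notes on the series. Compound 1 `CC(C)(C)c1ccc(OCCCON2C(N)=NC(N)=NC23CCSCC3)cc1` carries a tert-butyl on the aryl ether and in an assay on isolated protein for inhibition of Dihydrofolate reductase (Homo sapiens), read by spectrophotometry, using NADPH, with stated times of 5 s and 6 min, tested at 50 uM (on this read-out higher numbers stand for a stronger effect at the one concentration tested and lower numbers for a weaker effect), compound 1 gives 86.6%. Compound 3 `NC1=NC2(CCOCC2)N(OCCCOc2ccccc2Br)C(N)=N1`, with a different core and a bromine on its aryl ring, gives 85% in this assay; the gap to compound 1 is within the usual scatter, so the two are not told apart, although compound 1 holds the larger of the two reported numbers. Compound 2 `NC1=NC2(CCOCC2)N(OCCCOc2ccc(Cl)cc2)C(N)=N1` is recorded in this assay as "not determined" (no result reported), so no number is reported for compound 2. Within the data shown here, no pair of measured compounds differs in a single place, so no step size is established within the set.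

Compound 4 `COc1ccc(OCCCON2C(N)=NC(N)=NC23CCSCC3)cc1` keeps the core of compound 1 and differs from it only as follows: methoxy in place of tert-butyl on an aromatic carbon. With the two measured numbers lying close together across different aryl substituents and cores, no change beyond the scatter is expected from compound 1 to compound 4 in this assay, and the step is estimated as a number 6.6 percentage points lower from compound 1 to compound 4 (within the scatter). Compound 4 is therefore expected to give about 80% in this assay, with a likely range from 60% to 93%.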

Compound 4, a percentage reported as inhibition, at one concentration (the size of the read-out at that concentration, not a potency): 86.6%
Compound 4: middle estimate off by 6.6 percentage points, on the low side; low and high end bracket the measured number.
By their numbers in this assay, from the lowest: compounds 3, 1 and 4 (each within the scatter of the next).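

In this assay, among these compounds, methoxy in place of tert-butyl on an aromatic carbon gives no change at the digits printed from compound 1 to compound 4 (within the scatter), the first step that isolates one position on a shared core. At this position, a group of 4 heavy atoms, all carbon, and no hydrogen-bond acceptor gives way to one of 2 heavy atoms with 1 hydrogen-bond acceptor, and the read-out does not separate the two compounds. No accompanying measurement speaks to why this step reads as it does.

As far as these compounds go, a single-concentration read-out gives the size of the effect and not a potency, so whether the two compounds differ in potency stays open. Also open, from the compounds shown here alone, are how a carboxylic acid or an amine at this aromatic carbon would read, and whether the same change would read alike on the core of compound 3.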